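Swapping a Chloropyrimidine for a Trifluoromethylpyridine

The source may report more compounds than this note shows. Statements on the series, on what has been measured and on what is new or still open speak of the compounds shown alone.

Compound 1 `Cc1nc(C(=O)N2CC3(CC3)C[C@H]2CNc2ncc(Cl)cn2)c(-c2ccccc2)s1` is tested in a functional assay on HEK293 cells for antagonist activity at Orexin receptor type 2 (Homo sapiens), read by FLIPR and calcium flux (a higher number here means a more potent compound, by a factor of ten per unit of this negative logarithm, a lower number a less potent compound), where compound 1 gives 6.8, the lower of the two numbers recorded. Compound 3 `Cc1ccc(-c2nccs2)c(C(=O)N2CC3(CC3)C[C@H]2CNc2ccc(C(F)(F)F)cn2)n1`, which carries a different aryl amide on the same core, gives 8 in this assay. Compound 2 `Cc1nc(C(=O)N2CCC3(CC3)C[C@H]2CNc2ccc(C(F)(F)F)cn2)c(-c2ccccc2)s1`, built on a larger core, reaches only the limit (the limit of < 5 in this assay, at which 1 of the 3 values shown sits), so its value < 5 in this assay is a limit of the assay and not a number. Compound 4 `Cc1nc(C(=O)N2CC3(CC3)C[C@H]2CNc2ccc(C(F)(F)F)cn2)c(-c2ccccc2)s1` keeps the core of compound 1 and changes one group: 5-(trifluoromethyl)pyridin-2-yl in place of 5-chloropyrimidin-2-yl on an amine nitrogen. Among the measured compounds shown here, no measured pair covers this change, so the expected step from compound 1 to compound 4 in this assay a number 0.40 log units higher from compound 1 to compound 4 (beyond the scatter) is a modest gain, close to the scatter. Compound 4 is therefore estimated at 7.2, between 6.4 and 8 in this assay.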

Compound 4, negative logarithm of the antagonist equilibrium constant: 7.7
Estimate against measurement, compound 4: 0.50 log units below; measured number inside the range.
By their numbers in this assay, from the lowest: compound 1; then compounds 4 and 3 (each within the scatter of the next). At a limit, below all of these: compound 2.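

Changing the ring on the amine nitrogen matters on this core: a number 0.90 log units higher from compound 1 to compound 4 (beyond the scatter) in this assay is a step that lies beyond the scatter of the measurement. Compound 2, which carries the same 5-(trifluoromethyl)pyridin-2-yl on a larger core, gives < 5, a limit of the assay and not a number. Nothing measured here explains the gain.

The exchange alters the ring and its substituent together, so their shares cannot be separated. As far as these compounds go, how 5-chloropyridin-2-yl or 5-cyanopyridin-2-yl would read on this amine nitrogen stays open.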